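This account rests on a few compounds, and the source may have more. Where it says the series, first, only, none or still open, it means among the compounds named here.

Series notes. Compound 1 `COc1cc(-c2cc(/C=C/C(=O)c3ccc(N)cc3)[nH]n2)cc(OC)c1OC` is measured in a functional assay on MOLT-4 cells (Homo sapiens) for cytotoxicity, read by sulforhodamine B assay, with a stated time of 48 h, tested at 0.01 uM (on this read-out lower numbers stand for a stronger effect and higher numbers for a weaker effect at the one concentration tested), and gives 101%. On the three numbers recorded, compound 1 stands second highest. Its nearest neighbour is compound 3 `COc1ccc(-c2cc(/C=C/C(=O)c3cc(OC)c(OC)c(OC)c3)[nH]n2)cc1OC`, which in this assay gives 99%; the two values lie within the scatter of each other. Furthest from it is compound 2 `COc1ccc(-c2cc(/C=C/C(=O)c3ccc(N)cc3)[nH]n2)cc1OC`, which in this assay gives 108%. For the measured compounds named here, the one step recorded between measured compounds, hydrogen in place of methoxy on an aromatic carbon, amounts to a number 7 percentage points higher from compound 1 to compound 2 (within the scatter) and stays within the scatter. All three numbers sit near the unaffected level at the single concentration.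

Compound 4 `COc1ccc(C(=O)/C=C/c2cc(-c3cc(OC)c(OC)c(OC)c3)n[nH]2)cc1OC` is the next to be measured. It differs from compound 1 by 3,4-dimethoxyphenyl in place of 4-aminophenyl on a carbonyl carbon. Going by the values given here, no measured step bears directly on this exchange: the recorded step from compound 1 to compound 2 concerns another part of the molecule, and compound 3, which also carries an aryl group other than 4-aminophenyl on the carbonyl carbon, is not a single-change partner of compound 1, so its value shows only that such a variation gave a number in the same range. Since compound 1 gives 101% and compound 3 gives 99%, no step beyond the scatter is expected in this assay for compound 4. The step from compound 1 to compound 4 is estimated at a number 1 percentage points lower from compound 1 to compound 4 (within the scatter). Compound 4 is accordingly expected to give 100%, in the range 88% to 112%.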

Compound 4, a percentage reported as activity, at one concentration (the size of the read-out at that concentration, not a potency): 102%
Estimate against measurement, compound 4: 2 percentage points below, and the stated range covers the measured number.
By their numbers in this assay, from the lowest: compounds 3, 1, 4 and 2 (each within the scatter of the next).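

In this assay, the exchange of 4-aminophenyl for 3,4-dimethoxyphenyl on the carbonyl carbon can now be read directly as a single change, and it gives a number 1 percentage points higher from compound 1 to compound 4 (within the scatter). For the compounds shown here, the one earlier step concerned another part of the molecule, so this is the first reading at this position: a larger aryl group with two methoxy groups, and no hydrogen-bond donor, takes the place of the 4-aminophenyl group without a step beyond the scatter at the one concentration tested. No supporting information on this result is available, and the flat reading remains a plain observation without an explanation.

Going by these compounds, all the compounds shown sit near the unaffected level at this single low concentration, so it remains open whether either aryl group would separate from the other at a concentration where the series has a clear effect. On these data alone, it also remains open whether a group of a different kind on the carbonyl carbon, such as a carboxylic acid or a dimethylamino-substituted phenyl, would move the number beyond the scatter.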